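A few compounds are considered here, and "the series" means these few. Any claim that something is new, unique, unknown or untested is made for them only; others in the source may bear on it.

Compound 1 `COc1ccc(CS(=O)(=O)/C=C/c2ccc(C)cc2C)cc1`: 12000 nM
Compound 2 `COc1ccc(CS(=O)(=O)/C=C/c2c(C)cccc2C)cc1`: > 20000 nM (a limit, not a number)

Both compounds were tested in a functional assay on DU-145 cells (Homo sapiens) for antiproliferative activity, read by trypan blue exclusion; on this read-out higher numbers stand for weaker inhibition and lower numbers for stronger inhibition. Compound 1 gives 12000 nM in this assay. For compound 2 the assay reports only a limit, > 20000 nM, and this is the limit of > 20000 nM in this assay, at which 1 of the 2 values shown sits. Compound 2 therefore stands at the weak end of the two results shown, with no exact number behind it.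

Compound 3 `COc1ccc(CS(=O)(=O)/C=C/c2c(C)cc(C)cc2C)cc1` has not yet been measured. It differs from compound 2 by methyl in place of hydrogen on an aromatic carbon. Among the compounds with values here, no step between two measured compounds is available to lean on, so the size of the step cannot be read from any earlier pair. The expected step from compound 2 to compound 3 is a number no higher from compound 2 to compound 3 (the limit leaves the size open), that is, no movement beyond the scatter. Compound 3 is expected to give about 20000 nM, within 8000 nM to 50000 nM, and it is quite possible that this assay again returns only a limit for it.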

Compound 3, half-maximal inhibitory concentration: > 20000 nM
Compound 3: no number, only a limit (the forecaster's own chance of this, stated with the estimate: 55%); the middle value lies on the limit itself.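

In this assay compound 3 also gives only a limit, > 20000 nM, so a methyl para to a large group does not bring compound 2 back to a readable number, and the step between these two cannot be read. Compared with compound 1, the added methyl gives an at least 1.6-fold higher number from compound 1 to compound 3 (0.22 log units; that floor lies within the scatter), so the change points toward weaker inhibition, but the smallest step the data allow does not by itself establish a real loss. The read-out now offers little room to separate these compounds: the limit of > 20000 nM in this assay, at which 2 of the 3 values shown sit.

As far as these compounds go, how far compound 2 and compound 3 lie past the limit remains unknown. From the compounds shown here alone, it also remains open whether an amine or a carboxylic acid at this same place would give a measurable value.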